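Vinyl-to-ethyl swap on the amide carbonyl: series notes

This account rests on a few compounds, and the source may have more. Where it says the series, first, only, none or still open, it means among the compounds named here.

Compound 1 `CCC(=O)NCc1ccc(C(=O)Nc2ccc(C)c(Nc3nccc(-c4cccnc4)n3)c2)cc1`: > 10000 nM
Compound 2 `C=CC(=O)NCc1ccc(C(=O)Nc2ccc(C)c(Nc3nccc(-c4cccnc4)n3)c2)cc1`: > 10000 nM
Compound 3 `C=CC(=O)Nc1cc(C(=O)Nc2ccc(C)c(Nc3nccc(-c4cccnc4)n3)c2)cc(C(F)(F)F)c1`: 5460 nM

In an ADME assay on BaF3 cells (Mus musculus) for cytotoxicity, read by CellTiter-Glo and CCK-8 assay, with a stated time of 72 h (a lower number here means a stronger inhibitor of growth, a higher number a weaker inhibitor of growth), compound 1 gives only a limit, > 10000 nM. In this assay compound 2 also gives only a limit, > 10000 nM. For the measured compounds named here, compound 3 is the one compound with a number, 5460 nM in this assay. The difference between the core of compound 3 and that of compound 2 is not broken down here.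

From compound 2 to compound 1 the change is ethyl in place of vinyl on a carbonyl carbon, and the measured step is a step that the two limits leave unreadable from compound 2 to compound 1 because of the limit of > 10000 nM in this assay, at which 2 of the 3 values shown sit. Compound 4 `CCC(=O)Nc1cc(C(=O)Nc2ccc(C)c(Nc3nccc(-c4cccnc4)n3)c2)cc(C(F)(F)F)c1` carries the same change on the core of compound 3: ethyl in place of vinyl on a carbonyl carbon, at the same place.

The measured pair gives no readable size, so the expectation for compound 4 rests on compound 3 at 5460 nM. The step from compound 3 to compound 4 is expected to be a 2.2-fold higher number from compound 3 to compound 4 (0.34 log units; beyond the scatter). Compound 4 is estimated at 12000 nM, between 5000 nM and 30000 nM.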

Compound 4, concentration for 50% growth inhibition: > 10000 nM
Compound 4: no number, only a limit; the forecaster's own chance of this, stated with the estimate: 60%; the middle value does not contradict the limit.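

In this assay compound 4 gives only a limit, > 10000 nM. Ethyl in place of vinyl on the carbonyl carbon therefore gives an at least 1.8-fold higher number from compound 3 to compound 4 (0.26 log units; that floor lies within the scatter), a floor and not a measured size, so this result does not establish a real change on this core. The step on the core of compound 2 cannot be read either, and no size can be compared between the two cores because of where the values sit: the limit of > 10000 nM in this assay, at which 3 of the 4 values shown sit.

Open, from the compounds shown here alone, is how an amine or a longer chain such as butanoyl in place of the vinyl on this carbonyl carbon would read in this assay. Also open, going by these compounds, is how the core of compound 3 would read with a nitrile in place of trifluoromethyl.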